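A Methylphenyl Swap Among Inactive Triazoles

The source may hold more compounds than are shown below. What is called first, only, known or untested is meant among the compounds shown, and "the series" means these compounds.

Measured in a functional assay on DU-145 cells (Homo sapiens) for antiproliferative activity, read by MTT assay, with a stated time of 48 h (a lower number here means a stronger inhibitor, a higher number a weaker inhibitor), with every value a limit:
Compound 1 `COc1ccccc1-n1cc(COC(=O)/C(C)=C/CC/C(C)=C/CC/C(C)=C/CC[C@@H]2[C@@]3(C)CCC(=O)C(C)(C)[C@H]3CC[C@@]2(C)O)nn1`: > 150000 nM
Compound 2 `C/C(=C\CC/C(C)=C/CC[C@@H]1[C@@]2(C)CCC(=O)C(C)(C)[C@H]2CC[C@@]1(C)O)CC/C=C(\C)C(=O)OCc1cn(-c2cccc(Br)c2)nn1`: > 150000 nM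
Compound 3 `C/C(=C\CC/C(C)=C/CC[C@@H]1[C@@]2(C)CCC(=O)C(C)(C)[C@H]2CC[C@@]1(C)O)CC/C=C(\C)C(=O)OCc1cn(-c2cccc(F)c2)nn1`: > 150000 nM

Compound 3 gives no number, only the limit > 150000 nM. The other two compounds also sit at a limit, as the limit of > 150000 nM in this assay, at which 3 of the 3 values shown sit, records. The next compound, compound 4 `C/C(=C\CC/C(C)=C/CC[C@@H]1[C@@]2(C)CCC(=O)C(C)(C)[C@H]2CC[C@@]1(C)O)CC/C=C(\C)C(=O)OCc1cn(-c2ccc(C)cc2)nn1`, replaces the 3-fluorophenyl of compound 3 with 4-methylphenyl on an aromatic nitrogen of the five-membered ring: 4-methylphenyl in place of 3-fluorophenyl on an aromatic nitrogen. Among the measured compounds shown here, two measured steps bear most directly on this change, as both alter the same aryl group. One is a step that the two limits leave unreadable from compound 1 to compound 3 and the other is a step that the two limits leave unreadable from compound 2 to compound 3. Neither has a readable size, so they give no direction and no scale for the new change. Three different aryl groups have left the read-out at the same limit, so the simplest expectation is no real change. The expected step is a step that the limit leaves unreadable from compound 3 to compound 4, with no direction favoured. Compound 4 is expected to lie near 160000 nM. The estimated range for this value runs from 70000 nM to 300000 nM, and a reported limit is the likeliest outcome.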

Compound 4, half-maximal inhibitory concentration: > 150000 nM
Compound 4 was reported as a limit; the forecaster's own chance of this, stated with the estimate: 80%; the middle value lies beyond the limit too.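

Compound 4 is reported only as a limit, as are compound 1, compound 2 and compound 3, so no step among these four compounds can be read: the limit of > 150000 nM in this assay, at which 4 of the 4 values shown sit.

The compounds shown leave open whether any aryl group on the shared core gives a readable value in this assay.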